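Changing the Aryl Group on the Ring Nitrogen

A few compounds are considered here, and "the series" means these few. Any claim that something is new, unique, unknown or untested is made for them only; others in the source may bear on it.

In an in vitro functional assay on HEK293-A cells for positive allosteric modulation of metabotropic glutamate receptor 5 (Homo sapiens), read by FLIPR and calcium flux (on this read-out higher numbers stand for an effect only at larger amounts of compound and lower numbers for an effect already at smaller amounts), compound 1 `O=C1CC(c2nc(-c3cccc(Cl)c3)no2)CN1c1ccc(Cl)cc1` gives 140 nM. Compound 2 `O=C1CC(c2nc(-c3cccc(Cl)c3)no2)CN1c1ccc(Cl)c(Cl)c1` gives 460 nM in this assay. Compound 3 `Cc1ccccc1N1CC(c2nc(-c3cccc(Cl)c3)no2)CC1=O` reaches only a limit of > 10000 nM in this assay, so it stands at the weak end of the values shown (the limit of > 10000 nM in this assay, at which 1 of the 3 values shown sits).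

Compound 4 `COc1cccc(N2CC(c3nc(-c4cccc(Cl)c4)no3)CC2=O)c1` differs from compound 3 by 3-methoxyphenyl in place of 2-methylphenyl on an amide-type nitrogen in a ring. Two measured steps change the same aryl group: an at least 71-fold higher number from compound 1 to compound 3 (1.85 log units; beyond the scatter) and an at least 21-fold higher number from compound 2 to compound 3 (1.33 log units; beyond the scatter), both large losses. Among the compounds with values here, no measured step shows the 3-methoxyphenyl itself, so the direction for compound 4 is uncertain; a return toward the values of compound 1 and compound 2 is possible, but not assured. The expected step is an at least 4.0-fold lower number from compound 3 to compound 4 (0.60 log units; beyond the scatter). Compound 4 is estimated at 2500 nM, within 300 nM to 10000 nM.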

Compound 4, half-maximal effective concentration: > 10000 nM
Compound 4 was reported as a limit (the forecaster's own chance of this, stated with the estimate: 35%); middle value at least 4.0-fold (0.60 log units) away from the limit.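

In this assay compound 4 also stops at a limit, > 10000 nM, so a second aryl group without chlorine joins compound 3 at the weak end: the limit of > 10000 nM in this assay, at which 2 of the 4 values shown sit.

In place of 3,4-dichlorophenyl, 3-methoxyphenyl gives an at least 21-fold higher number from compound 2 to compound 4 (1.33 log units; beyond the scatter), and in place of 4-chlorophenyl it gives an at least 71-fold higher number from compound 1 to compound 4 (1.85 log units; beyond the scatter); the loss is therefore not confined to 2-methylphenyl. The step between compound 3 and compound 4 cannot be read, since both are limits.

The compounds shown leave open how a 4-methoxyphenyl or a 3-chlorophenyl on this ring nitrogen would read.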